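A few compounds are considered here, and "the series" means these few. Any claim that something is new, unique, unknown or untested is made for them only; others in the source may bear on it.

In a functional assay on HepG2 cells (Homo sapiens) for antiproliferative activity, read by CCK-8 assay, with a stated time of 48 h (on this read-out lower numbers stand for stronger inhibition and higher numbers for weaker inhibition), compound 1 `COc1ccc(/C=C\c2cc(OC)c(OC)c(OC)c2)cc1OCc1ccc(CN2CCCC[C@@H]2C(=O)O)cc1` gives > 10000 nM, which is a limit of the assay and not a number. Within the data shown here, compound 2 `COc1ccc(/C=C\c2cc(OC)c(OC)c(OC)c2)cc1OCc1ccc(CN2CCCCC2C(=O)NCCN)cc1` gives 4800 nM, the only actual number so far. Compound 3 `COc1ccc(/C=C\c2cc(OC)c(OC)c(OC)c2)cc1OCc1ccc(CN[C@H](C(=O)O)[C@@H](C)O)cc1` differs from it by (1-carboxy-2-hydroxypropyl)amino in place of 2-((2-aminoethyl)carbamoyl)piperidin-1-yl on a saturated chain carbon bound to an aromatic carbon, with (1-carboxy-2-hydroxypropyl)amino in place of 2-((2-aminoethyl)carbamoyl)piperidin-1-yl on a saturated chain carbon bound to an aromatic carbon. Among the measured compounds shown here, compound 3 carries a carboxy group, as compound 1 does, so the one measured step, an at least 2.0-fold lower number from compound 1 to compound 2 (0.31 log units; beyond the scatter), points to a modest move back toward higher numbers. The expected change is a 2.1-fold higher number from compound 2 to compound 3 (0.32 log units; beyond the scatter). For compound 3 the estimated value is 10000 nM, within an expected range of 4000 nM to 30000 nM.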

Compound 3, half-maximal inhibitory concentration: > 10000 nM
Compound 3: only a limit was reported (the forecaster's own chance of this, stated with the estimate: 55%); the middle value lies on the limit itself.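

In this assay compound 3 gives > 10000 nM and that is a limit of the assay, not a number. Replacing 2-((2-aminoethyl)carbamoyl)piperidin-1-yl by (1-carboxy-2-hydroxypropyl)amino on this saturated chain carbon gives an at least 2.0-fold higher number from compound 2 to compound 3 (0.31 log units; beyond the scatter) and so shows that an open-chain carboxy group does not keep the number of compound 2. Compound 1 and compound 3 both carry a carboxy group, and the step between them cannot be read: the limit of > 10000 nM in this assay, at which 2 of the 3 values shown sit. Still open, going by these compounds, is whether the 2-aminoethyl amide needs the piperidine ring, which that amide on the open chain of compound 3 would test. On these data alone, a methyl ester in place of the carboxylic acid also remains open.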